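Ethoxy for methoxy on a shifted benzamide core

The compounds below may be only part of what the source reports. "The series", "measured", "known", "first", "only" and "open" are said of these compounds alone.

Of the compounds shown here, three have been measured in an assay on isolated protein for inhibition of ribosomal protein S6 kinase alpha-2 (Homo sapiens), read by fluorescence, with a stated time of 20 min, tested at 10 uM; a lower number here means less inhibition, a higher number more inhibition at the concentration tested (going by the name of the read-out). Compound 1 `COc1ccc(NCN2C(=O)c3cccc(NC(=O)c4ccccc4)c3C2=O)cc1` gives 99.5% in this assay. Compound 3 `CCOc1ccc(NCN2C(=O)c3cccc(NC(=O)c4ccccc4)c3C2=O)cc1` gives 105% in this assay; it differs from compound 1 by methyl in place of hydrogen on a saturated chain carbon bound to an oxygen on an aromatic ring and the step of a number 5.5 percentage points higher from compound 1 to compound 3 (within the scatter) stays within the scatter. Compound 2 `COc1ccc(NCN2C(=O)c3ccc(NC(=O)c4ccccc4)cc3C2=O)cc1` gives 82% in this assay, the lowest of the three; it has the same atoms as compound 1 joined differently, and the difference between the two cores is not broken down here.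

Compound 4 `CCOc1ccc(NCN2C(=O)c3ccc(NC(=O)c4ccccc4)cc3C2=O)cc1` is not yet measured. It differs from compound 2 by methyl in place of hydrogen on a saturated chain carbon bound to an oxygen on an aromatic ring, the same change that leads from compound 1 to compound 3. Because the step of a number 5.5 percentage points higher from compound 1 to compound 3 (within the scatter) was within the scatter, a similarly small step is expected from compound 2 to compound 4 in this assay, namely a number 4 percentage points higher from compound 2 to compound 4 (within the scatter). Compound 4 is therefore estimated to give 86% in this assay, with an expected range from 70% to 100%.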

Compound 4, a percentage reported as inhibition, at one concentration (the size of the read-out at that concentration, not a potency): 69.5%
Compound 4: middle estimate off by 16.5 percentage points, on the high side, outside the stated range (below it).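

On the second of the two cores, the swap of methoxy for ethoxy gave a number 12.5 percentage points lower from compound 2 to compound 4 (beyond the scatter), so the small step seen on the first core did not hold there. In this assay the outcome of this one change differed with the core that carried it: the same change on two cores in this assay, a number 5.5 percentage points higher (within the scatter) from compound 1 to compound 3 and a number 12.5 percentage points lower (beyond the scatter) from compound 2 to compound 4, 18 percentage points apart, beyond the scatter of two such steps. This shows that a step read on one of these cores cannot simply be carried over to the other, but two pairs give no rule for the whole series and do not explain why the two cores part ways.

The compounds shown leave open how a longer chain such as propoxy, a branched isopropoxy group or an amine at the same place would behave on each core, and whether the gap between the cores would widen, narrow or reverse. As far as these compounds go, every reading here is also a single-concentration percentage, so how these compounds compare in potency remains open.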